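Trading azido for ethyl in compound 3

The source may report more compounds than this note shows. Statements on the series, on what has been measured and on what is new or still open speak of the compounds shown alone.

In a functional assay on LOX cells (Homo sapiens) for antiproliferative activity, read by WST assay, with a stated time of 3 days (on this read-out higher numbers stand for weaker inhibition and lower numbers for stronger inhibition), compound 1 (`[N-]=[N+]=Nc1cc(=O)[nH]c(=O)n1[C@@H]1O[C@H](CO)[C@@H](O)[C@H]1O`) reads > 50000 nM, which is a limit of the assay and not a number. Among the compounds with values here, compound 2 (`[N-]=[N+]=Nc1c(F)c(=O)[nH]c(=O)n1[C@@H]1O[C@H](CO)[C@@H](O)[C@H]1O`) gives 2300 nM, the only actual number so far. Fluoro in place of hydrogen on an aromatic carbon brings an at least 21-fold lower number from compound 1 to compound 2 (1.33 log units; beyond the scatter), a size that rests on (the limit of > 50000 nM in this assay, at which 1 of the 2 values shown sits).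

Compound 3 (`CCc1c(F)c(=O)[nH]c(=O)n1[C@@H]1O[C@H](CO)[C@@H](O)[C@H]1O`) keeps the fluoro and carries ethyl in place of azido on an aromatic carbon. Within the data shown here, the one measured step left azido untouched, so it gives no direct size for this change. With compound 2 at 2300 nM as the sole anchor, a moderate move towards a higher number in this assay, meaning weaker inhibition, is expected, though with wide uncertainty. The expected change is a 3.5-fold higher number from compound 2 to compound 3 (0.54 log units; beyond the scatter). For compound 3 the estimated value is 8000 nM, within an expected range of 1500 nM to 40000 nM.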

Compound 3, half-maximal inhibitory concentration: 4500 nM
For compound 3 the middle estimate is 1.8-fold (0.25 log units) above the measured one, and the stated range covers the measured number.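

In this assay, the azido group on this aromatic carbon, next to the ring nitrogen and ortho to a fluoro group, gives way to ethyl with a 2.0-fold higher number from compound 2 to compound 3 (0.29 log units; within the scatter), so with the fluoro kept, the two compounds cannot be told apart on this read-out. The step thus shows that azido is not needed for a measurable reading at this position: ethyl, with 2 carbon atoms, no double bond and no hydrogen-bond acceptor, serves in its place without a change beyond the scatter. No measurement given here accounts for this result.

The compounds shown leave open whether fluoro in place of hydrogen matters as much alongside ethyl as it does alongside azido. They also leave open how this position responds to an amine, a carboxylic acid or a longer chain such as propyl.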